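From compound 1 to compound 3 in one change

The source may report more compounds than this note shows. Statements on the series, on what has been measured and on what is new or still open speak of the compounds shown alone.

Measured so far in a physicochemical assay for lipophilicity, read by LC-MS, using the shake flask method, in phosphate buffer, with a stated time of 50 min, at pH 7.4; on this read-out lower numbers stand for lower lipophilicity and higher numbers for higher lipophilicity:
- Compound 1 `CCCC(=O)OCCCCCC(=O)N[C@H](C(=O)N1C[C@H](O)C[C@H]1C(=O)NCc1ccc(-c2scnc2C)cc1)C(C)(C)C` gives 0.5 in this measurement
- Compound 2 `CCCCOc1ccc(-c2ccc(C(=O)NCCCCCC(=O)N[C@H](C(=O)N3C[C@H](O)C[C@H]3C(=O)NCc3ccc(-c4scnc4C)cc3)C(C)(C)C)cc2)cc1` gives 1 in this measurement

Compound 1 stands at the lower of the two numbers, and compound 2 lies above it by a gap beyond the usual scatter.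

Compound 3 `Cc1ncsc1-c1ccc(CNC(=O)[C@@H]2C[C@@H](O)CN2C(=O)[C@@H](NC(=O)CCCCCNC(=O)C2CCCCC2)C(C)(C)C)cc1` has not yet been measured. Compared with compound 1, it carries (cyclohexylcarbonyl)amino in place of (propylcarbonyl)oxy on a saturated chain carbon, five bonds along the chain from a carbonyl carbon while the shared core stays the same. Within the data shown here, no measured step of this kind is available, so the expectation rests only on that structural change and on the two values in hand, with compound 2 at 1 as the upper one. In this assay a modest rise is expected, estimated as a number 0.40 log units higher from compound 1 to compound 3 (beyond the scatter) and so slightly beyond the scatter, though the evidence for it is thin. The estimate for compound 3 is 0.9 with an expected range from 0.3 to 1.5 for the coming measurement.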

Compound 3, distribution coefficient: 1.4
Compound 3: middle estimate off by 0.50 log units, on the low side, and the stated range covers the measured number.
By their numbers in this assay, from the lowest: compound 1; then compound 2; then compound 3.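

This position on the chain tolerates a substantial change in the group it carries, and the read-out responds to it: in this assay, (cyclohexylcarbonyl)amino in place of (propylcarbonyl)oxy on a saturated chain carbon, five bonds along the chain from a carbonyl carbon, gives a number 0.90 log units higher from compound 1 to compound 3 (beyond the scatter). Among these compounds, compounds 1 and 2 alone offered no step in one place, so this is the first size that can be attached to a change at this position. Among the compounds shown here, the single step nevertheless bundles several differences, as the entering group brings one six-membered non-aromatic ring of carbon only and a hydrogen-bond donor, and no measurement at hand bears on why the number moves as it does.

The compounds shown leave open how much of the step goes with the ring and how much with the change from oxy to amino, a split that (propylcarbonyl)amino or (cyclohexylcarbonyl)oxy at the same place would help to settle. Also open, going by these compounds, is how a free amine, a carboxylic acid or a longer chain would read in this assay.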